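Removing a Para Methyl from a Triazole-Linked Lactam

The source may report more compounds than this note shows. Statements on the series, on what has been measured and on what is new or still open speak of the compounds shown alone.

Measured so far in a functional assay on LoVo cells (Homo sapiens) for inhibition, read by MTT assay, with a stated time of 24 h; on this read-out higher numbers stand for weaker inhibition and lower numbers for stronger inhibition:
compound 1 `CC1(C)[C@H]2CC[C@]1(C)N(Cc1cn(-c3cccc(Cl)c3)nn1)C(=O)C2` gives 70 nM
compound 2 `CC1(C)[C@H]2CC[C@]1(C)N(Cc1cn(-c3ccccc3O)nn1)C(=O)C2` gives 540 nM
compound 3 `Cc1ccc(-n2cc(CN3C(=O)C[C@@H]4CC[C@@]3(C)C4(C)C)nn2)cc1` gives 50 nM

Going by the values given here, all three share the same bicyclic lactam core and a triazole carrying an aryl group; only that aryl group changes. Compound 3 and compound 1 cannot be told apart on these numbers, since a 1.4-fold lower number from compound 1 to compound 3 (0.15 log units; within the scatter). Compound 2 stands well apart from both, as a 7.7-fold higher number from compound 1 to compound 2 (0.89 log units; beyond the scatter) and an 11-fold lower number from compound 2 to compound 3 (1.03 log units; beyond the scatter).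

Compound 4 `CC1(C)[C@H]2CC[C@]1(C)N(Cc1cn(-c3ccccc3)nn1)C(=O)C2` has not yet been measured. It differs from compound 3 in one place: hydrogen in place of methyl on an aromatic carbon. The lost group sits para to a large group, and the change reads as 4-methylphenyl to phenyl.

Among the compounds with values here, no measured step removes a methyl on its own. The closest guide is the step from compound 1 to compound 3, where swapping one aryl substituent pattern for another stayed within the scatter; only the 2-hydroxyphenyl of compound 2 moved the number far. A plain phenyl is expected to behave like the other simple aryls, so the step of a 1.4-fold higher number from compound 3 to compound 4 (0.15 log units; within the scatter) is expected to stay within the scatter.

Compound 4 is therefore estimated at 70 nM, between 30 nM and 170 nM in this assay.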

Compound 4, half-maximal inhibitory concentration: 50 nM
Beside the measured number, compound 4's estimate is 1.4-fold (0.15 log units) above it, within the range that was stated.
By their numbers in this assay, from the lowest: compounds 3, 4 and 1 (each within the scatter of the next); then compound 2.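

In this assay, taking the methyl away leaves no change at the digits printed from compound 3 to compound 4 (within the scatter), so at this position, para to a large group, the methyl makes no measurable difference. Putting hydrogen in place of chloro gives a 1.4-fold lower number from compound 1 to compound 4 (0.15 log units; within the scatter), which is also within the scatter, while hydrogen in place of hydroxy gives an 11-fold lower number from compound 2 to compound 4 (1.03 log units; beyond the scatter). Compound 4 therefore shows that a phenyl with no added group already reaches the same range as compound 1 and compound 3, leaving compound 2 as the only one apart.

No available measurement explains why compound 2 gives the higher number. As far as these compounds go, whether an amine, a carboxylic acid or a longer chain such as butyl, para to a large group, would also leave the number unchanged remains open.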